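The source may hold more compounds than are shown below. What is called first, only, known or untested is meant among the compounds shown, and "the series" means these compounds.

In a functional assay on VCaP cells (Homo sapiens) for antiproliferative activity, read by propidium iodide staining, with a stated time of 96 h (a lower number here means a stronger inhibitor, a higher number a weaker inhibitor), compound 1 `CC(O)(COc1cccc(S(F)(F)(F)(F)F)c1)C(=O)Nc1cccc(S(F)(F)(F)(F)F)c1` gives 26700 nM, compound 2 `CC(O)(COc1ccc(C(F)(F)F)cc1)C(=O)Nc1cccc(S(F)(F)(F)(F)F)c1` gives 13300 nM and compound 3 `CC(O)(COc1cccc(C(F)(F)F)c1)C(=O)Nc1cccc(S(F)(F)(F)(F)F)c1` gives 22500 nM. Compound 3 thus lies within the usual scatter of both other compounds. Compound 4 `CC(O)(COc1ccccc1C(F)(F)F)C(=O)Nc1cccc(S(F)(F)(F)(F)F)c1` differs from compound 3 by a single change: 2-(trifluoromethyl)phenyl in place of 3-(trifluoromethyl)phenyl on an oxygen on a saturated carbon, with 2-(trifluoromethyl)phenyl in place of 3-(trifluoromethyl)phenyl on an oxygen on a saturated carbon. The closest measured change, 3-(trifluoromethyl)phenyl in place of 4-(trifluoromethyl)phenyl, gave a 1.7-fold higher number from compound 2 to compound 3 (0.23 log units; within the scatter). A change elsewhere in the structure gave a 1.2-fold lower number from compound 1 to compound 3 (0.07 log units; within the scatter). Among the compounds with values here, no measured compound carries 2-(trifluoromethyl)phenyl, so the direction remains open. The expected result in this assay is a 1.1-fold lower number from compound 3 to compound 4 (0.05 log units; within the scatter), so no step beyond the scatter is expected. For compound 4, the estimated value is 20000 nM, with an expected range of 9000 nM to 42000 nM.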

Compound 4, half-maximal inhibitory concentration: 36700 nM
The estimate for compound 4 lay 1.8-fold (0.26 log units) below the measured number; the range from low to high includes it.
By their numbers in this assay, from the lowest: compounds 2, 3, 1 and 4 (each within the scatter of the next, the first and the last beyond it).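

In this assay, 2-(trifluoromethyl)phenyl in place of 3-(trifluoromethyl)phenyl gives a 1.6-fold higher number from compound 3 to compound 4 (0.21 log units; within the scatter) and so remains within the scatter. The same group in place of 4-(trifluoromethyl)phenyl gives a 2.8-fold higher number from compound 2 to compound 4 (0.44 log units; beyond the scatter) and is the first step shown here that lies beyond the scatter, so the placement of trifluoromethyl on this phenyl can matter modestly. No available evidence explains this difference. The compounds shown leave open how a nitrile or an amine on this phenyl would read in this assay and whether any such group would give a lower number than compound 2.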